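The compounds below may be only part of what the source reports. "The series", "measured", "known", "first", "only" and "open" are said of these compounds alone.

Compound 1 `Cc1nc(N(C)Cc2ccccc2)nc(-n2ccnc2C)c1[N+](=O)[O-]` gives 30000 nM in a functional assay on cells (Osteoclast-like, Homo sapiens) for inhibition, read by colony formation; on this read-out higher numbers stand for weaker inhibition and lower numbers for stronger inhibition. Compound 2 `Cc1nc(NC2CCc3ccccc32)nc(-n2ccnc2C)c1[N+](=O)[O-]` gives 40000 nM in this assay, so compound 1 shows the lower of the two numbers, though the gap to compound 2 is within the scatter and both sit at weak inhibition. Compound 3 `Cc1nc(N(C)c2ccccc2)nc(-n2ccnc2C)c1[N+](=O)[O-]` differs from compound 1 by phenyl in place of benzyl on a nitrogen on an aromatic ring. Going by the values given here, no measured pair mirrors this change, and nothing among the two known numbers points in either direction, so no step beyond the scatter is expected. For compound 3 in this assay the estimate is 35000 nM, with a range from 12000 nM to 100000 nM. The expected step of a 1.2-fold higher number from compound 1 to compound 3 (0.07 log units; within the scatter) is judged to stay within the scatter.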

Compound 3, half-maximal inhibitory concentration: 30000 nM
Estimate against measurement, compound 3: 1.2-fold (0.07 log units) above; the range from low to high includes it.
By their numbers in this assay, from the lowest: compounds 1, 3 and 2 (each within the scatter of the next).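

In this assay, going by these compounds alone, phenyl in place of benzyl on a nitrogen on an aromatic ring gives no change at the digits printed from compound 1 to compound 3 (within the scatter), the first step that changes one place only. At this position, the two aromatic groups cannot be told apart, and inhibition remains weak. No supporting data explain this flat result.

Open, from the compounds shown here alone, is whether a longer chain such as phenethyl, or an amine or a carboxylic acid carried on the phenyl ring, would move the number beyond the scatter.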